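Ester chain length and rat microsomal half-life

The source may hold more compounds than are shown below. What is called first, only, known or untested is meant among the compounds shown, and "the series" means these compounds.

Measured compounds:
compound 1 `CCOc1cc(NC(=O)C2(NC(=O)c3ccc4c(C5CCCC5)c(-c5ncc(Cl)cn5)n(C)c4c3)CCC2)ccc1/C=C/C(=O)OC(=O)C[C@H](O)C(=O)O` — 7.92 h
compound 2 `CCOc1cc(NC(=O)C2(NC(=O)c3ccc4c(C5CCCC5)c(-c5ncc(Cl)cn5)n(C)c4c3)CCC2)ccc1/C=C/C(=O)OCOP(=O)(O)OC(C)(C)C` — 0.133 h
compound 3 `CCOC(=O)/C=C/c1ccc(NC(=O)C2(NC(=O)c3ccc4c(C5CCCC5)c(-c5ncc(Cl)cn5)n(C)c4c3)CCC2)cc1OCC` — 3.07 h

All three share one core and differ only in the group on the ester oxygen. In an ADME assay (liver) for pharmacokinetics, with Liver microsome (Rattus norvegicus) as the target, using microsomes (on this read-out lower numbers stand for a shorter-lived compound and higher numbers for a longer-lived compound), compound 3 stands second highest of the three numbers. Its nearest neighbour is compound 1: a 2.6-fold lower number from compound 1 to compound 3 (0.41 log units; beyond the scatter). Its furthest is compound 2: a 23-fold higher number from compound 2 to compound 3 (1.36 log units; beyond the scatter).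

Compound 4 `CCCOC(=O)/C=C/c1ccc(NC(=O)C2(NC(=O)c3ccc4c(C5CCCC5)c(-c5ncc(Cl)cn5)n(C)c4c3)CCC2)cc1OCC` is the next member. Relative to compound 3 the change is methyl in place of hydrogen on a saturated chain carbon, two bonds along the chain from an oxygen next to a carbonyl group; cut one bond further out it reads ethyl to propyl, or ethoxy to propoxy.

Going by the values given here, no measured step touches this position. The step from compound 1 to compound 3 replaced a larger acyl group on the ester oxygen and moved the number modestly; the step from compound 2 to compound 3 removed a phosphate-bearing chain and moved it a great deal. Neither involves a single added carbon on the ester chain, so the expectation for compound 4 rests on compound 3 alone, with no step beyond the scatter anticipated in this assay.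

Compound 4 is therefore estimated at 2.5 h, with a range of 1 h to 6 h; this expected step is a 1.2-fold lower number from compound 3 to compound 4 (0.09 log units; within the scatter).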

Compound 4, half-life: 0.35 h
For compound 4 the middle estimate is 7.1-fold (0.85 log units) above the measured one; measured number below the stated range.
By their numbers in this assay, from the lowest: compound 2; then compound 4; then compound 3; then compound 1.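

In this assay, ethyl to propyl on an oxygen next to a carbonyl group is a large change for one added carbon (an 8.8-fold lower number from compound 3 to compound 4 (0.94 log units; beyond the scatter)), so a single methyl in place of hydrogen at this saturated chain carbon is enough to move the number beyond the scatter. Compound 4 now lies much nearer the phosphorus-bearing compound 2 (a 2.6-fold higher number from compound 2 to compound 4 (0.42 log units; beyond the scatter)) than the acylated compound 1 (a 23-fold lower number from compound 1 to compound 4 (1.35 log units; beyond the scatter)), and group size alone does not order the series: compound 1 and compound 2 both carry larger groups yet fall at opposite ends. No supporting data explain the effect of the added methyl on this read-out.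

Open, going by these compounds, is whether butyl or a longer chain continues the fall or levels off. Isopropyl would show whether branching at this carbon gives a different number from the straight propyl.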